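Removing the aryl methyl from the thiophene amide

The compounds below may be only part of what the source reports. "The series", "measured", "known", "first", "only" and "open" are said of these compounds alone.

In an assay on HEK293 cells for agonist activity at transient receptor potential cation channel subfamily M member 8 (Homo sapiens), read by fluorescence and calcium flux, with a stated time of 15 min (on this read-out higher numbers stand for an effect only at larger amounts of compound and lower numbers for an effect already at smaller amounts), compound 1 `CCN(Cc1cccs1)C(=O)COc1ccc(C)cc1` gives 8 nM, the lowest number among the three measured compounds. Compound 3 `CCN(Cc1ccco1)C(=O)COc1ccc(C)cc1` gives 489 nM in this assay, and compound 2 `CCN(Cc1c[nH]nn1)C(=O)COc1ccc(C)cc1` gives 31100 nM. The steps measured so far all change the ring on the saturated chain carbon bound to the amide-type nitrogen: a 61-fold higher number from compound 1 to compound 3 (1.79 log units; beyond the scatter), a 3900-fold higher number from compound 1 to compound 2 (3.59 log units; beyond the scatter) and a 64-fold lower number from compound 2 to compound 3 (1.80 log units; beyond the scatter). Each is large, and each leaves the rest of the molecule untouched.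

Compound 4 `CCN(Cc1cccs1)C(=O)COc1ccccc1` differs from compound 1 at a different place: hydrogen in place of methyl on an aromatic carbon. Within the data shown here, no measured step touches this six-membered ring, so the three steps above say nothing direct about the size of this change; they only show that the thiophen-2-yl group of compound 1, the one that carries the large effects seen so far, is kept in compound 4 and that everything else is shared. With that group retained, a move of the size seen for the heteroaryl swaps is not expected; a small shift toward a higher number, possibly within the scatter, seems the likelier outcome. Compound 4 is therefore expected to give 25 nM in this assay, with a range from 8 nM to 100 nM, which means an expected step of a 3.1-fold higher number from compound 1 to compound 4 (0.49 log units; beyond the scatter).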

Compound 4, half-maximal effective concentration: 1400 nM
Compound 4: the middle estimate sits 56-fold (1.75 log units) below what was measured; measured number outside the range, above it.
By their numbers in this assay, from the lowest: compound 1; then compound 3; then compound 4; then compound 2.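

In this assay, the methyl on the aromatic carbon para to a large group turns out to matter as much as the heteroaryl ring: a 180-fold higher number from compound 1 to compound 4 (2.24 log units; beyond the scatter) is a large step, as are the ring swaps on the other side of the amide. Among these compounds, the six-membered aromatic ring of carbon only, which no earlier step touched, is therefore a second place where the read-out is highly sensitive, and with thiophen-2-yl retained, the loss of a single heavy atom is enough to produce this step. Nothing available explains why this one methyl carries so much weight.

As far as these compounds go, it remains open whether an ethyl, a chlorine or a methoxy at the same aromatic carbon would keep the number near that of compound 1 or move it further, so the methyl result cannot yet be read as a trend for this position. Among the compounds shown here, it is also open whether hydrogen in place of methyl costs as much when furan-2-yl or 1H-1,2,3-triazol-4-yl takes the place of thiophen-2-yl, since the only step at this position carries the thiophene.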